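Ethylating the Amide Nitrogen of an Inactive Analogue

The source may report more compounds than this note shows. Statements on the series, on what has been measured and on what is new or still open speak of the compounds shown alone.

Compound 1 `CCC1C(=O)N(C)c2cnc(-n3ccc4cc(C(N)=O)ccc43)nc2N1c1ccn(C)n1` is the starting point. In a functional assay on MCF7 cells (Homo sapiens) for antiproliferative activity, read by CCK-8 assay, with a stated time of 72 h (on this read-out lower numbers stand for stronger inhibition of growth and higher numbers for weaker inhibition of growth), compound 1 gives "not active" (no number reported), so it stands without a number against the others. Compound 4 `CCNC(=O)c1ccc2c(ccn2-c2ncc3c(n2)N(c2ccn(C)n2)C(CC)C(=O)N3C)c1` differs from compound 1 by ethyl in place of hydrogen on an amide-type nitrogen. Compound 2 `CC[C@@H]1C(=O)N(C)c2cnc(-n3ccc4cc(C(N)=O)ccc43)nc2N1C1CCCC1` gives 1830 nM and compound 3 `CCCNC(=O)c1ccc2c(ccn2-c2ncc3c(n2)N(C2CCCC2)[C@H](CC)C(=O)N3C)c1` gives 592 nM. Among the measured compounds shown here, the only comparable step shows a 3.1-fold lower number from compound 2 to compound 3 (0.49 log units; beyond the scatter). That pair carries a different group on the other nitrogen of the shared core, and compound 1 itself showed no measurable activity, so the gain may not fully carry over. A modest improvement in the same direction is expected for compound 4 in this assay, though a limit rather than a number remains possible. Compound 4 is expected at 6000 nM, within 1500 nM to 30000 nM.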

Compound 4, concentration for 50% growth inhibition: 13200 nM
Estimate against measurement, compound 4: 2.2-fold (0.34 log units) below, within the range that was stated.
By their numbers in this assay, from the lowest: compound 3; then compound 2; then compound 4.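

In this assay, among the compounds shown here, compound 1 has no number, so no step from it to compound 4 can be read. No evidence here bears on this result. The compounds shown leave open how much ethyl in place of the amide hydrogen alone changes growth inhibition.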